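The compounds below may be only part of what the source reports. "The series", "measured", "known", "first", "only" and "open" are said of these compounds alone.

Among the measured compounds shown here, in a physicochemical assay for lipophilicity (on this read-out lower numbers stand for lower lipophilicity and higher numbers for higher lipophilicity), compound 3 `O=C(Nc1ccccc1)Nc1ccc(OC2=NS(=O)(=O)c3ccccc32)cc1` gives 2.89, the second highest of the three numbers measured so far. Compound 1 `O=C(Nc1ccc(NC2=NS(=O)(=O)c3ccccc32)cc1)Nc1cccc(Br)c1` gives 2.24 in this assay, and compound 2 `O=C(Nc1ccc(Cl)cc1)Nc1ccc(OC2=NS(=O)(=O)c3ccccc32)cc1` gives 3.55. Compound 4 `O=C(Nc1ccc(OC2=NS(=O)(=O)c3ccccc32)cc1)Nc1ccccc1Cl` differs from compound 3 by chloro in place of hydrogen on an aromatic carbon. For the measured compounds named here, the one measured step that bears on this change runs the opposite way: a number 0.66 log units lower from compound 2 to compound 3 (beyond the scatter). Going by the values given here, a rise of about that size is therefore expected when the chloro is put back on, though no measured pair covers a chloro that sits ortho to a large group, so the expected step is set a little smaller, at a number 0.51 log units higher from compound 3 to compound 4 (beyond the scatter). Compound 4 is accordingly estimated at 3.4, within a range from 3 to 3.8.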

Compound 4, partition coefficient: 3.55
Estimate against measurement, compound 4: 0.15 log units below, within the range that was stated.
By their numbers in this assay, from the lowest: compound 1; then compound 3; then compounds 2 and 4 (each within the scatter of the next).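

In this assay, chloro in place of hydrogen on an aromatic carbon ortho to a large group gives a number 0.66 log units higher from compound 3 to compound 4 (beyond the scatter), so the rise tied to 4-chlorophenyl also appears with 2-chlorophenyl. Changing 4-chlorophenyl to 2-chlorophenyl gives no change at the digits printed from compound 2 to compound 4 (within the scatter), so these two placings of the chloro cannot be told apart on this read-out. No supporting evidence is available to explain this match. As far as these compounds go, whether a methoxy group, a nitrile or an amine on the same aromatic carbon would give a similar step remains open.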